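The source may report more compounds than this note shows. Statements on the series, on what has been measured and on what is new or still open speak of the compounds shown alone.

Measured so far:
compound 1, `CC1(C)C[C@H](O)C[C@](C)(CNC(=O)c2ccccc2O)C1` — > 50000 nM
compound 2, `CC1(C)C[C@H](O)C[C@](C)(CNc2n[nH]c3ccccc23)C1` — > 100000 nM
compound 3, `CC1(C)C[C@H](O)C[C@](C)(CNc2ccccn2)C1` — > 100000 nM

In an ADME assay on MDCK cells (Canis lupus familiaris) for cytotoxicity, read by MTT assay, with a stated time of 3 days (on this read-out higher numbers stand for lower toxicity in this test and lower numbers for higher toxicity in this test), compound 1 gives > 50000 nM, which is a limit of the assay and not a number. Compound 2 gives > 100000 nM, also a limit. Compound 3 stands at > 100000 nM, again a limit rather than a measured value. For the measured compounds named here, because every value shown is a limit (the limit of > 100000 nM in this assay, at which 2 of the 3 values shown sit, (the limit of > 50000 nM in this assay, at which 1 of the 3 values shown sits)), no step between measured compounds can be sized, and compound 3 is indistinguishable from the others on these numbers.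

Compound 4, `CC1(C)C[C@H](O)C[C@](C)(CNc2ccc(C(F)(F)F)cn2)C1`, differs from compound 3 by trifluoromethyl in place of hydrogen on an aromatic carbon. Going by the values given here, with no measured step to lean on, compound 4 is expected to sit at the limit as well, with no step beyond the scatter: a number no higher from compound 3 to compound 4 (the limit leaves the size open). The estimate for compound 4 is 100000 nM, between 30000 nM and 300000 nM.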

Compound 4, half-maximal cytotoxic concentration: 30500 nM
The estimate for compound 4 lay 3.3-fold (0.52 log units) above the measured number; low and high end bracket the measured number.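

In this assay, trifluoromethyl in place of hydrogen on an aromatic carbon, two atoms from the ring nitrogen, gives an at least 3.2-fold lower number from compound 3 to compound 4 (0.51 log units; beyond the scatter). For the compounds shown here, this position can therefore move the read-out off the limit, towards higher toxicity in this test, which none of the earlier compounds showed. The full size of the step cannot be read because compound 3 stands at a limit: the limit of > 100000 nM in this assay, at which 2 of the 4 values shown sit.

As far as these compounds go, it remains open whether a methyl, a chlorine or a nitrile at this place would shift the number as well. From the compounds shown here alone, it is equally open whether an amine or a carboxylic acid there would leave it at the limit.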